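From a Hydroxypropynyl Handle to a Hexyl Chain

The source may hold more compounds than are shown below. What is called first, only, known or untested is meant among the compounds shown, and "the series" means these compounds.

In an ADME assay on L1210/0 cells (Mus musculus) for cytotoxicity, with a stated time of 48 h (a lower number here means a stronger inhibitor, a higher number a weaker inhibitor), compound 1 `Cc1ccc(S(=O)(=O)/C=C/[C@H]2O[C@@H](n3cnc4c(N)ncnc43)[C@@H](O)[C@H]2O)cc1` gives 54000 nM and compound 2 `Nc1ncnc2c1ncn2[C@H]1C[C@@H](O)[C@@H](C=O)O1` gives 26600 nM. Compound 3 `O=c1[nH]c(=O)n([C@H]2C[C@H](O)[C@@H](CO)O2)cc1C#CCO` stands apart: in this assay it reaches only a limit, > 200000 nM, so no number is known for it; this is the limit of > 200000 nM in this assay, at which 1 of the 3 values shown sits. Compound 4 `CCCCCCc1cn([C@H]2C[C@H](O)[C@@H](CO)O2)c(=O)[nH]c1=O` has not yet been measured. It differs from compound 3 in one place: hexyl in place of 3-hydroxyprop-1-yn-1-yl on an aromatic carbon. Among the compounds with values here, with no measured step between two compounds to lean on, the change is expected to move the result in this assay by little beyond the scatter and in no firm direction, the estimated step being an at least 1.3-fold lower number from compound 3 to compound 4 (0.12 log units; that floor lies within the scatter). Compound 4 is therefore expected to give about 150000 nM, within 30000 nM to 600000 nM, with a fair chance that it too comes back only as a limit.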

Compound 4, half-maximal inhibitory concentration: > 200000 nM
Compound 4 was reported as a limit; the forecaster's own chance of this, stated with the estimate: 55%; at least 1.3-fold (0.12 log units) between middle value and limit.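

Within the data shown here, compound 3 and compound 4 both come back only as limits, so no step between them can be read: the limit of > 200000 nM in this assay, at which 2 of the 4 values shown sit.

In this assay, from the compounds shown here alone, the size and direction of the change from 3-hydroxyprop-1-yn-1-yl to hexyl stay open.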